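The source may hold more compounds than are shown below. What is called first, only, known or untested is meant among the compounds shown, and "the series" means these compounds.

In a functional assay on Rec1 cells (Homo sapiens) for inhibition, read by luminescence and CellTiter-Glo, with a stated time of 72 h (on this read-out lower numbers stand for stronger inhibition and higher numbers for weaker inhibition), compound 1 (`C=CC(=O)Nc1ccc(Cn2nc(-c3ccc(Oc4ccccc4)cc3)cc2C(=O)O)cc1`) gives > 60000 nM, a limit of the assay and not a number, so it stands at the weak end of the three values measured. Compound 2 (`C=CC(=O)Nc1ccc(Cn2nc(-c3ccc(Oc4ccccc4)cc3)cc2C(=O)OCC)cc1`) gives 2800 nM and compound 3 (`C=CC(=O)Nc1ccc(Cn2nc(-c3ccc(Oc4ccccc4)cc3)cc2CO)cc1`) gives 3500 nM. Compound 4 (`O=C(CCl)Nc1cccc(Cn2nc(-c3ccc(Oc4ccccc4)cc3)cc2C(=O)O)c1`) keeps the carboxy group of compound 1 and differs as follows: 3-(((chloromethyl)carbonyl)amino)phenyl in place of 4-((vinylcarbonyl)amino)phenyl on a saturated chain carbon bound to an aromatic nitrogen. In words, 3-(((chloromethyl)carbonyl)amino)phenyl stands in place of 4-((vinylcarbonyl)amino)phenyl on a saturated chain carbon bound to an aromatic nitrogen. The measured steps all alter the carboxy group instead. Two are large, an at least 21-fold lower number from compound 1 to compound 2 (1.33 log units; beyond the scatter) and an at least 17-fold lower number from compound 1 to compound 3 (1.23 log units; beyond the scatter), while the third is small, a 1.3-fold higher number from compound 2 to compound 3 (0.10 log units; within the scatter). Among the compounds with values here, since compound 4 retains that group, a drop like an at least 21-fold lower number from compound 1 to compound 2 (1.33 log units; beyond the scatter) is not expected to carry over, and no measured step tests the new group, so only a modest move towards lower numbers is expected, perhaps none beyond the scatter. The expected change is an at least 1.5-fold lower number from compound 1 to compound 4 (0.17 log units; that floor lies within the scatter). For compound 4 the estimated value is 40000 nM, with an expected range of 10000 nM to 60000 nM.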

Compound 4, half-maximal inhibitory concentration: 7100 nM
Compound 4: middle estimate off by 5.6-fold (0.75 log units), on the high side; the measured number lies below the stated range.
By their numbers in this assay, from the lowest: compounds 2 and 3 (each within the scatter of the next); then compound 4. At a limit, above all of these: compound 1.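

In this assay, the swap on a saturated chain carbon bound to an aromatic nitrogen gives an at least 8.4-fold lower number from compound 1 to compound 4 (0.92 log units; beyond the scatter), the first measured change away from the carboxy group. Within the data shown here, compound 4 keeps that carboxy group, so altering the carboxy group is not the only change that moves the series away from the weak end. The full size of this step stays unknown, because its starting point is a limit and not a number: the limit of > 60000 nM in this assay, at which 1 of the 4 values shown sits.

The step changes two things at once, vinyl to chloromethyl and 4- to 3- in the group's name, so the compounds shown do not say which one matters. On these data alone, a 3-((vinylcarbonyl)amino)phenyl group at this place would separate the two, and it remains open how the new group behaves alongside an ethoxycarbonyl or hydroxymethyl group.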